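The compounds below may be only part of what the source reports. "The series", "measured", "known", "first", "only" and "open" are said of these compounds alone.

Working notes on a small series read out in an assay on Sf9 cells for inhibition of protein deacetylase HDAC6 (Homo sapiens), read by fluorescence, with a stated time of 40 min, tested at 100 nM; on this read-out higher numbers stand for more inhibition at the one concentration tested (going by the name of the read-out) and lower numbers for less inhibition. Compound 1 `O=C(NO)c1ccc(NCc2nc(-c3cccs3)nn2-c2ccc(O)cc2)cc1` gives 79.6% in this assay. Compound 2 `O=C(NO)c1ccc(NCc2nc(-c3ccco3)nn2-c2ccccc2)cc1` gives 59.9% in this assay. Compound 2 holds the lower of the two numbers recorded so far; the nearest number, that of compound 1, lies higher by a gap beyond the usual scatter. Compound 1 and compound 2 differ in more than one place, so nothing is drawn from that gap about any single change.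

Compound 3 `O=C(NO)c1ccc(NCc2nc(-c3ccc(Cl)cc3)nn2-c2ccccc2)cc1` is not yet measured. It differs from compound 2 in one place: 4-chlorophenyl in place of furan-2-yl on an aromatic carbon. The change puts 4-chlorophenyl in place of furan-2-yl on an aromatic carbon between two ring nitrogen atoms. Among the measured compounds shown here, no measured pair shows this change, so neither size nor direction can be read off for it from the data. Expected is a step of a number 5.1 percentage points higher from compound 2 to compound 3 (within the scatter), small, with the direction open and a modest rise taken as the likelier outcome. Compound 3 is expected to give about 65% in this assay, within a range from 45% to 82%.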

Compound 3, a percentage reported as inhibition, at one concentration (the size of the read-out at that concentration, not a potency): 67.2%
Estimate against measurement, compound 3: 2.2 percentage points below, and the stated range covers the measured number.
By their numbers in this assay, from the lowest: compounds 2 and 3 (each within the scatter of the next); then compound 1.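

The step at the aromatic carbon between two ring nitrogen atoms is a number 7.3 percentage points higher from compound 2 to compound 3 (within the scatter) in this assay, with 4-chlorophenyl in place of furan-2-yl. At this position in this pair, a five-membered aromatic ring with 1 hetero atom and a six-membered aromatic ring of carbon only therefore give values within the scatter of each other, although the entering group has more heavy atoms and the hydrogen-bond acceptor counted on furan-2-yl is gone. No measurement on hand gives a reason for this outcome.

Among the compounds shown here, this single pair covers only two aromatic groups, so an amine, a carboxylic acid or a longer chain on this aromatic carbon remains an open case, and nothing yet tells how such groups would read in this assay. Going by these compounds, compound 1 differs from compound 2 and from compound 3 in more than one place, so how much of the higher value of compound 1 (79.6%) belongs to the group on this carbon and how much to the other change remains open as well.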